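The source may report more compounds than this note shows. Statements on the series, on what has been measured and on what is new or still open speak of the compounds shown alone.

Measured in an assay on isolated protein (strain Sprague-Dawley) for inhibition of Amine oxidase [flavin-containing] B (Rattus norvegicus), read by spectrophotometry, with a stated time of 5 min; on this read-out lower numbers stand for stronger inhibition and higher numbers for weaker inhibition:
compound 1 `CCCOc1cc(=O)oc2cc(OCc3cccc(F)c3)ccc12`, 407 nM
compound 2 `CCOc1cc(=O)oc2cc(OCc3cccc(Cl)c3)ccc12`, 115 nM
compound 3 `COc1cc(=O)oc2cc(OCc3cccc(Br)c3)ccc12`, 5.75 nM

Compound 2 gives the second highest of the three numbers; compound 1 is nearest, with a higher number beyond the scatter, and compound 3 is furthest, with a lower number beyond the scatter. Each measured compound differs from the others at two places at once, so no single step can be read between them. Compound 4 `Nc1cc(=O)oc2cc(OCc3cccc(Cl)c3)ccc12` is compound 2 with amino in place of ethoxy on an aromatic carbon. Nothing measured isolates this change. For compound 4 the step in this assay is expected to be modest and toward weaker inhibition, estimated as a 2.2-fold higher number from compound 2 to compound 4 (0.34 log units; beyond the scatter). Compound 4 is expected to give about 250 nM, within 50 nM to 1500 nM.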

Compound 4, half-maximal inhibitory concentration: 47.9 nM
Beside the measured number, compound 4's estimate is 5.2-fold (0.72 log units) above it; the measured number lies below the stated range.
By their numbers in this assay, from the lowest: compound 3; then compound 4; then compound 2; then compound 1.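

In this assay, among the compounds shown here, amino in place of ethoxy on the aromatic carbon opposite the ring oxygen gives a 2.4-fold lower number from compound 2 to compound 4 (0.38 log units; beyond the scatter), the only single-place comparison so far. This position therefore accepts a group with fewer heavy atoms and a hydrogen-bond donor without any loss of inhibition, and the modest step goes toward stronger inhibition. Nothing measured here accounts for the step. Still open, on these data alone, is whether it follows from the amino group itself or from the loss of the ethoxy chain. A methylamino or dimethylamino group on this carbon would separate the two.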